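Ethyl to Hydrogen on the Core of Compound 2

The source may report more compounds than this note shows. Statements on the series, on what has been measured and on what is new or still open speak of the compounds shown alone.

Three inhibitors built on a related core have been characterised in an assay for inhibition of Caspase-8 (Homo sapiens); a higher number here means a weaker inhibitor, a lower number a stronger inhibitor. Compound 1 `CCC(C(=O)N[C@@H](CC(=O)O)C(=O)CNCN1CCCCC1)n1cc(C(C)(C)C)nc(NCc2nonc2C)c1=O` returns only > 10000 nM, which is a limit of the assay rather than a number (the limit of > 10000 nM in this assay, at which 1 of the 3 values shown sits). Compound 2 `CCCCCCN(C)CNCC(=O)[C@H](CC(=O)O)NC(=O)C(CC)n1cc(CC)nc(NCc2nonc2C)c1=O` gives 9540 nM in this assay, and of the two numbers recorded it is the higher one. Compound 3 `CCC(C(=O)N[C@@H](CC(=O)O)C(=O)CSCc1ccccc1)n1ccnc(NCc2nc(C)no2)c1=O` gives 6420 nM in this assay, a gap from compound 2 that sits within the usual scatter, so the two cannot be told apart.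

Compound 4 `CCCCCCN(C)CNCC(=O)[C@H](CC(=O)O)NC(=O)C(CC)n1ccnc(NCc2nonc2C)c1=O` is the next compound, and it differs from compound 2 in one place: hydrogen in place of ethyl on an aromatic carbon. Among the compounds with values here, no pair among the measured compounds shows this exact change, so its effect is not yet known from the numbers. The step from compound 2 to compound 4 in this assay is expected to be modest, a 1.2-fold higher number from compound 2 to compound 4 (0.06 log units; within the scatter), with no change beyond the scatter or at most a slight weakening. Compound 4 is therefore estimated at 11000 nM in this assay, with a likely range from 4000 nM to 30000 nM, and there is a fair chance that the assay reports only a limit for it.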

Compound 4, half-maximal inhibitory concentration: > 10000 nM
Compound 4 gave a limit, no number (the forecaster's own chance of this, stated with the estimate: 45%); the middle value is on the limit's open side.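

In this assay compound 4 gives > 10000 nM, which is a limit of the assay and not a number. This is the first pair among the compounds shown to isolate this aromatic carbon, next to the ring nitrogen, and hydrogen in place of ethyl gives an at least 1.0-fold higher number from compound 2 to compound 4 (0.02 log units; that floor lies within the scatter), so the change yields no stronger inhibitor, while the floor of the step does not establish any real weakening. The true size of the step stays unresolved, as the value of compound 4 joins those resting at the top of the readable range: the limit of > 10000 nM in this assay, at which 2 of the 4 values shown sit.

On these data alone, whether a methyl group, a longer alkyl chain or an amine on this aromatic carbon would move the number in this assay remains open. Also open, as far as these compounds go, is how large the change from ethyl to hydrogen would be on a partner compound whose values lie well clear of the limit, where both sides of the step could be read as numbers.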